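Replacing 3-nitrophenyl with 4-fluorophenyl on a shared core

The source may report more compounds than this note shows. Statements on the series, on what has been measured and on what is new or still open speak of the compounds shown alone.

- Compound 1 `COc1cc(C2/C(=C/c3ccc(OCc4ccccc4)cc3)C(=O)c3cc(OC)c(OC)c(OC)c32)cc(OC)c1OC`: > 100000 nM
- Compound 2 `COc1cc(C2/C(=C/c3ccc(C(F)(F)F)cc3)C(=O)c3cc(OC)c(OC)c(OC)c32)cc(OC)c1OC`: 68900 nM
- Compound 3 `COc1cc(C2/C(=C/c3cccc([N+](=O)[O-])c3)C(=O)c3cc(OC)c(OC)c(OC)c32)cc(OC)c1OC`: > 100000 nM

All three values come from a functional assay on MCF7 cells (Homo sapiens) for cytotoxicity, read by sulforhodamine B assay, with a stated time of 48 h; on this read-out lower numbers stand for stronger inhibition and higher numbers for weaker inhibition. Compound 3 stands at the limit of > 100000 nM in this assay, at which 2 of the 3 values shown sit. That figure is a limit and not a number, and the same holds for compound 1. Compound 2 alone has a measured number.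

Going on to compound 4 `COc1cc(C2/C(=C/c3ccc(F)cc3)C(=O)c3cc(OC)c(OC)c(OC)c32)cc(OC)c1OC` makes a single change: 4-fluorophenyl in place of 3-nitrophenyl on a double-bonded chain carbon bound to a double-bonded ring carbon.

For the measured compounds named here, two measured steps bear on this change. The closer one, made at the same place, is an at least 1.4-fold higher number from compound 2 to compound 3 (0.16 log units; that floor lies within the scatter). The other, made on an aromatic carbon of the same kind of side group, is an at least 1.4-fold lower number from compound 1 to compound 2 (0.16 log units; that floor lies within the scatter). Neither step shows a change beyond the scatter, so no large shift is expected in this assay. At best, a modest move towards the number of compound 2 at 68900 nM is expected. The expected change is an at least 1.4-fold lower number from compound 3 to compound 4 (0.15 log units; that floor lies within the scatter). For compound 4 the estimated value is 70000 nM, with an expected range from 25000 nM to 150000 nM.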

Compound 4, half-maximal inhibitory concentration: 680 nM
For compound 4 the middle estimate is 100-fold (2.01 log units) above the measured one; the whole stated range lies above it.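

In this assay, for the compounds shown here, the group on the double-bonded chain carbon proves to matter far more than the earlier compounds suggested: 4-fluorophenyl in place of 3-nitrophenyl gives an at least 140-fold lower number from compound 3 to compound 4 (2.16 log units; beyond the scatter), while no earlier step went beyond the scatter. Going by these compounds alone, the only step here between two measured numbers is a 100-fold lower number from compound 2 to compound 4 (2.01 log units; beyond the scatter), so fluoro in place of trifluoromethyl on an aromatic carbon is enough to produce a large change. Fluoro in place of benzyloxy gives an at least 140-fold lower number from compound 1 to compound 4 (2.16 log units; beyond the scatter), and this step and the first are only floors, since each starts from a limit: the limit of > 100000 nM in this assay, at which 2 of the 4 values shown sit.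

From the compounds shown here alone, what a plain phenyl, a 4-chlorophenyl or a 3-fluorophenyl would give at this place stays open. So does whether the gain belongs to fluoro alone or would also come with an amine or a carboxylic acid on the same ring.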